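Trading 4-Chlorophenyl for 3,4-Dimethylphenyl

A few compounds are considered here, and "the series" means these few. Any claim that something is new, unique, unknown or untested is made for them only; others in the source may bear on it.

Measured in a functional assay on HCT-116 cells (Homo sapiens) for inhibition, read by CCK-8 assay, with a stated time of 48 h; a higher number here means a weaker inhibitor, a lower number a stronger inhibitor:
Compound 1, `COc1cc(-c2ccnc3cc(-c4ccc(Cl)cc4)nn23)cc(OC)c1OC`, gives 3340 nM.
Compound 2, `COc1cc(-c2ccnc3cc(-c4ccc(N(C)C)cc4)nn23)cc(OC)c1OC`, gives 2050 nM.
Compound 3, `COc1cc(-c2ccnc3cc(-c4ccc5c(ccn5C)c4)nn23)cc(OC)c1OC`, gives 39 nM.

Compound 1 stands highest of these three numbers. Its nearest neighbour is compound 2, reached by a 1.6-fold lower number from compound 1 to compound 2 (0.21 log units; within the scatter); its furthest is compound 3, reached by an 86-fold lower number from compound 1 to compound 3 (1.93 log units; beyond the scatter), and compound 2 to compound 3 shows a 53-fold lower number from compound 2 to compound 3 (1.72 log units; beyond the scatter).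

Compound 4, `COc1cc(-c2ccnc3cc(-c4ccc(C)c(C)c4)nn23)cc(OC)c1OC`, differs from compound 1 as follows: 3,4-dimethylphenyl in place of 4-chlorophenyl on an aromatic carbon.

The large drops both involve 1-methyl-1H-indol-5-yl, a fused two-ring group. Compound 4 keeps a single six-membered aromatic ring of carbon only, as in compound 1 and compound 2, so the step from compound 1 to compound 2 is the closer guide, and only a small shift, if any beyond the scatter, is expected in this assay. Compound 4 is therefore estimated at 2500 nM, within 800 nM to 8000 nM. The expected step is a 1.3-fold lower number from compound 1 to compound 4 (0.13 log units; within the scatter).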

Compound 4, half-maximal inhibitory concentration: 261 nM
Estimate against measurement, compound 4: 9.6-fold (0.98 log units) above; the whole stated range lies above it.
By their numbers in this assay, from the lowest: compound 3; then compound 4; then compounds 2 and 1 (each within the scatter of the next).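

In this assay, a fused two-ring group is not required for a large change at this position: a single six-membered aromatic ring of carbon only, as 3,4-dimethylphenyl, brings a 13-fold lower number from compound 1 to compound 4 (1.11 log units; beyond the scatter) and a 7.9-fold lower number from compound 2 to compound 4 (0.90 log units; beyond the scatter). The fused 1-methyl-1H-indol-5-yl group still holds the lowest number, with a 6.7-fold higher number from compound 3 to compound 4 (0.83 log units; beyond the scatter). Nothing measured here explains these steps. As far as these compounds go, whether both methyl groups of 3,4-dimethylphenyl are needed stays open, and so does how a methoxy group or a longer chain such as ethyl would behave on that ring.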